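From Methyl to Trifluoromethoxy in Liver Microsomes

A few compounds are considered here, and "the series" means these few. Any claim that something is new, unique, unknown or untested is made for them only; others in the source may bear on it.

In an in vitro ADME assay on microsomes from liver (Mus musculus) for pharmacokinetics, read by LC-MS (on this read-out higher numbers stand for fast clearance and lower numbers for slow clearance), compound 1 `Cc1cccc2c1nc(C)n2-c1ccc(C(=O)NC2CC2)s1` gives 66 mL/min/kg as a measured number. Compound 2 `Cc1ccc2c(c1)nc(C)n2-c1ccc(C(=O)NC2CC2)s1` gives > 72 mL/min/kg in the same read-out, and that value is a limit, not a number. Compound 2 therefore stands with the limit of > 72 mL/min/kg in this assay, at which 1 of the 2 values shown sits, and has no exact clearance.

Compound 3 `Cc1nc2cc(OC(F)(F)F)ccc2n1-c1ccc(C(=O)NC2CC2)s1` differs from compound 2 in one place (trifluoromethoxy in place of methyl on an aromatic carbon) and the change is trifluoromethoxy in place of methyl on an aromatic carbon. Within the data shown here, no measured step in this assay speaks to this change, so the expectation is loose. Among the measured compounds shown here, with compound 1 at 66 mL/min/kg as the only number in hand, clearance is expected to stay high. A downward step of modest size is expected, not far beyond the scatter, and a result that again reaches the limit would be no surprise. The estimated change is an at least 1.4-fold lower number from compound 2 to compound 3 (0.15 log units; that floor lies within the scatter) and it remains only an expectation. For compound 3 the estimated clearance is 50 mL/min/kg with an expected range from 25 mL/min/kg to 72 mL/min/kg in this assay when a number is reported.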

Compound 3, clearance: 43 mL/min/kg
Compound 3: middle estimate off by 1.2-fold (0.07 log units), on the high side, within the range that was stated.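

With trifluoromethoxy on this aromatic carbon, meta to a fused ring and para to a fused ring, compound 3 gives a measured number in this assay, so a change at this place can now be read at all. Trifluoromethoxy in place of methyl gives an at least 1.6-fold lower number from compound 2 to compound 3 (0.22 log units; that floor lies within the scatter), which fixes only a floor for the step and leaves its true size unknown. The step can be stated only as a floor because compound 2 carries a limit and not a number: the limit of > 72 mL/min/kg in this assay, at which 1 of the 3 values shown sits.

The compounds shown hold a single change at this place, so it remains open whether the reading belongs to trifluoromethoxy in particular or would also appear with chlorine, methoxy, a nitrile or an amine on the same carbon. Also open, on these data alone, is how trifluoromethoxy would read at the aromatic carbon where compound 1 carries its methyl, and whether a carboxylic acid or a longer chain elsewhere on the shared core would shift the clearance in the same direction.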